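Imidazoline for guanidine on a cytotoxicity series

A few compounds are considered here, and "the series" means these few. Any claim that something is new, unique, unknown or untested is made for them only; others in the source may bear on it.

The compounds share an aryl nitrogen carrying either an open guanidine-like group or a five-membered ring. Compound 2 `N=C(N)Nc1ccc(Oc2ccccc2)cc1` carries the open group on a core bearing a phenoxy substituent; compound 1 `c1ccc(Oc2ccc(NC3=NCCN3)cc2)cc1` carries the ring on the same core. Compound 3 `N=C(N)Nc1ccc2c(c1)OCCO2` carries the open group on a different core, and compound 4 `c1cc2c(cc1NC1=NCCN1)OCCO2`, not yet measured, carries the ring on that core. The difference between the two cores is not broken down here.

In an ADME assay on L6 cells (Rattus norvegicus) for cytotoxicity (a higher number here means a weaker inhibitor, a lower number a stronger inhibitor), compound 2 gives 59900 nM. In this assay compound 1 gives 167000 nM. The change a group of 5 heavy atoms (3 carbon, 2 nitrogen; one five-membered non-aromatic ring with 2 hetero atoms) in place of a group of 3 heavy atoms (1 carbon, 2 nitrogen; no ring), on a nitrogen on an aromatic ring thus produced a 2.8-fold higher number from compound 2 to compound 1 (0.45 log units; beyond the scatter). For compound 3 the result in this assay is only a limit, > 391000 nM.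

The change from compound 3 to compound 4 is a group of 5 heavy atoms (3 carbon, 2 nitrogen; one five-membered non-aromatic ring with 2 hetero atoms) in place of a group of 3 heavy atoms (1 carbon, 2 nitrogen; no ring), on a nitrogen on an aromatic ring; the place is described in the same words for both pairs, so it is the same change. Transferred to the other core, the step is expected to be comparable in size and direction, as a step that the limit leaves unreadable from compound 3 to compound 4. That expectation rests on the step from compound 2 to compound 1 a 2.8-fold higher number from compound 2 to compound 1 (0.45 log units; beyond the scatter) and on compound 3 already sitting at the limit of > 391000 nM in this assay, at which 1 of the 3 values shown sits. For compound 4 the estimated outcome in this assay is 600000 nM, most likely again reported only as a limit.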

Compound 4, half-maximal inhibitory concentration: > 351000 nM
Compound 4 gave a limit, no number (the forecaster's own chance of this, stated with the estimate: 80%); the middle value lies beyond the limit too.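

In this assay compound 3 is reported only as a limit, > 391000 nM. Compound 4 is likewise reported only as a limit, > 351000 nM. For the compounds shown here, no step can therefore be read between compound 3 and compound 4. The compounds shown leave open whether the five-membered ring, in place of the open group, changes the result on the core of compound 3 at all, and by how much.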